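Lengthening the amide chain on a macrolide side arm

The source may hold more compounds than are shown below. What is called first, only, known or untested is meant among the compounds shown, and "the series" means these compounds.

Measured compounds and their readings in a physicochemical assay for lipophilicity, read by HPLC, measured as chromatographic lipophilicity, at pH 7.4; a lower number here means a more polar compound, a higher number a more lipophilic compound:
- compound 1 `CC[C@H]1OC(=O)[C@H](C)[C@@H](O[C@H]2C[C@@](C)(OC)[C@@H](OCCCNC(C)=O)[C@H](C)O2)[C@H](C)[C@@H](O[C@@H]2O[C@H](C)C[C@H](N(C)C)[C@H]2O)[C@](C)(O)C[C@@H](C)CN(C)[C@H](C)[C@@H](O)[C@]1(C)O`: 2.06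
- compound 2 `CC[C@H]1OC(=O)[C@H](C)[C@@H](O[C@H]2C[C@@](C)(OC)[C@@H](O)[C@H](C)O2)[C@H](C)[C@@H](O[C@@H]2O[C@H](C)C[C@H](N(C)C)[C@H]2O)[C@](C)(O)C[C@@H](C)CN(C)[C@H](C)[C@@H](OCCCNC(=O)COC)[C@]1(C)O`: 2.58
- compound 3 `CC[C@H]1OC(=O)[C@H](C)[C@@H](O[C@H]2C[C@@](C)(OC)[C@@H](O)[C@H](C)O2)[C@H](C)[C@@H](O[C@@H]2O[C@H](C)C[C@H](N(C)C)[C@H]2O)[C@](C)(O)C[C@@H](C)CN(CCCNC(=O)c2c(C)nn(C)c2Cl)[C@H](C)[C@@H](O)[C@]1(C)O`: 2.2

Compound 1 gives the lowest of the three numbers in this assay. The reading of compound 3 lies within the usual scatter of that of compound 1, so the two cannot be told apart. The reading of compound 2 lies beyond the scatter above compound 1, so compound 2 is the more lipophilic of that pair. No two of the measured compounds differ in only one place, so none of these gaps can be tied to a single structural change.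

Compound 4 `CCCCCCCC(=O)NCCCO[C@H]1[C@H](C)O[C@@H](O[C@H]2[C@H](C)[C@@H](O[C@@H]3O[C@H](C)C[C@H](N(C)C)[C@H]3O)[C@](C)(O)C[C@@H](C)CN(C)[C@H](C)[C@@H](O)[C@](C)(O)[C@@H](CC)OC(=O)[C@@H]2C)C[C@@]1(C)OC` has not yet been measured in this assay. It differs from compound 1 in one place: hexyl in place of hydrogen on a saturated chain carbon bound to a carbonyl carbon. The hexyl chain that enters brings no rings, no donors and no acceptors, only saturated carbon. Going by the values given here, with no matched step among the measured compounds, the size of the effect rests on the nature of the added group alone; a rise beyond the scatter is expected, and the step from compound 1 to compound 4 is estimated at a number 1.94 log units higher from compound 1 to compound 4 (beyond the scatter). Compound 4 is therefore expected to read about 4 in this assay, with a plausible range from 3.3 to 4.8.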

Compound 4, distribution coefficient: 4.1
Compound 4: the middle estimate sits 0.10 log units below what was measured, within the range that was stated.
By their numbers in this assay, from the lowest: compounds 1 and 3 (each within the scatter of the next); then compound 2; then compound 4.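

Hexyl in place of hydrogen on a saturated chain carbon bound to a carbonyl carbon gives a number 2.04 log units higher from compound 1 to compound 4 (beyond the scatter) and is the first gap in this assay that can be tied to a single structural change. The earlier compounds shown here differ in more than one place and could not show this, whereas this pair shows that a change made at this place alone, read one bond further out as acetamido to (heptylcarbonyl)amino, is enough to produce a large step. Nothing measured here accounts for the size of that step.

With only this one pair, the compounds shown do not tell whether the reading follows the length of the chain, since neither a shorter addition such as ethyl nor a longer chain such as decyl appears among them. As far as these compounds go, it also stays open how far the number would move with an amine or a carboxylic acid in place of hexyl, and whether hexyl would give a step of like size on the side arms of compound 2 or compound 3.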